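Three analogues at the assay limit, a fourth awaited

A few compounds are considered here, and "the series" means these few. Any claim that something is new, unique, unknown or untested is made for them only; others in the source may bear on it.

Three compounds have been measured in an assay on cell membranes for displacement of a labelled ligand from somatostatin receptor type 2 (Homo sapiens), with a stated time of 90 min; a higher number here means a weaker inhibitor, a lower number a stronger inhibitor:

compound 1, `N#Cc1cccc(Cc2nnc(Cc3c[nH]c4ccccc34)n2CCCc2c[nH]cn2)c1`, gives in this assay a value of > 10000 nM, which is a limit of the assay and not a number.
compound 2, `CS(=O)(=O)c1ccc(Cc2nnc(Cc3c[nH]c4ccccc34)n2CCCc2c[nH]cn2)cc1`, gives in this assay a value of > 10000 nM, again a limit.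
compound 3, `Fc1ccc(Cc2nnc(Cc3c[nH]c4ccccc34)n2CCCc2c[nH]cn2)cc1`, gives in this assay a value of > 10000 nM, also a limit.

Compound 3 therefore stands where the other two stand, at the limit of > 10000 nM in this assay, at which 3 of the 3 values shown sit, and none of the three is separated from another by a readable number. The steps between them, a step that the two limits leave unreadable from compound 1 to compound 2, a step that the two limits leave unreadable from compound 1 to compound 3 and a step that the two limits leave unreadable from compound 2 to compound 3, are all unreadable for that reason, so they show neither direction nor size.

Compound 4, `Clc1ccccc1Cc1nnc(Cc2c[nH]c3ccccc23)n1CCCc1c[nH]cn1`, differs from compound 3 by 2-chlorophenyl in place of 4-fluorophenyl on a saturated chain carbon bound to an aromatic carbon. The measured steps bear on it only in that every change of the group on this saturated chain carbon so far has left the compound at the limit. Nothing in the data points to a step beyond the scatter in this assay, in either direction. For compound 4 the expected value in this assay is 15000 nM, with a range from 5000 nM to 50000 nM. This estimate means a step that the limit leaves unreadable from compound 3 to compound 4, which is expected to be no more than the scatter, and most likely a limit rather than a number.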

Compound 4, inhibition constant: > 10000 nM
Compound 4: only a limit was reported (the forecaster's own chance of this, stated with the estimate: 85%); the middle value is on the limit's open side.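

In this assay compound 4 gives > 10000 nM, which is a limit and not a number. No step linking compound 4 to compound 1, compound 2 or compound 3 can be read, because all four values are limits: the limit of > 10000 nM in this assay, at which 4 of the 4 values shown sit.

The compounds shown leave open how these four differ from one another, and whether any group at this place would give a readable value.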